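This account rests on a few compounds, and the source may have more. Where it says the series, first, only, none or still open, it means among the compounds named here.

Working notes on the series. Compound 1 `NCc1c[nH]c2ccc(F)cc12` and compound 2 `CCNCCCc1c[nH]c2ccc(F)cc12` share one core and differ only in the chain carrying the amine. Going by the values given here, in an assay on urine for inhibition of Myeloperoxidase (Homo sapiens) (on this read-out higher numbers stand for weaker inhibition and lower numbers for stronger inhibition), compound 1 gives 900 nM, and compound 2 gives 300 nM; the step of a 3.0-fold lower number from compound 1 to compound 2 (0.48 log units; beyond the scatter) is the only measured step so far, and it leaves compound 2 with the lower of the two numbers.

Compound 3 `NCCCCCCc1c[nH]c2ccc(F)cc12` is not yet measured. The change from compound 2 is 3-aminopropyl in place of ethylamino on a saturated chain carbon, three bonds along the chain from an aromatic carbon, so the amine is carried further out on a longer saturated chain, with the same count of donors and acceptors. Among the compounds with values here, the one step that bears on it, a 3.0-fold lower number from compound 1 to compound 2 (0.48 log units; beyond the scatter), went in the lowering direction when the chain grew; a second lengthening has no direct precedent, so the expectation is a step from compound 2 to compound 3 of about a 1.2-fold lower number from compound 2 to compound 3 (0.08 log units; within the scatter), not clearly beyond the scatter. Compound 3 is expected at 250 nM in this assay, within 100 nM to 700 nM.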

Compound 3, half-maximal inhibitory concentration: 260 nM
Beside the measured number, compound 3's estimate is 1.0-fold (0.02 log units) below it; low and high end bracket the measured number.
By their numbers in this assay, from the lowest: compounds 3 and 2 (each within the scatter of the next); then compound 1.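

In this assay, replacing ethylamino with 3-aminopropyl on a saturated chain carbon, three bonds along the chain from an aromatic carbon, gives a 1.2-fold lower number from compound 2 to compound 3 (0.06 log units; within the scatter), so compound 2 and compound 3 cannot be told apart at this position. Unlike a 3.0-fold lower number from compound 1 to compound 2 (0.48 log units; beyond the scatter), this change, with the same count of donors and acceptors on both sides, gives no step beyond the scatter, which shows that this further extension of the chain, with a primary amine in place of the ethylamino end, is tolerated without a clear change in the number. Nothing available explains why the two compounds read alike.

Still open, going by these compounds, is whether a longer chain would move the number beyond the scatter. Also open, on these data alone, is whether a hydroxyl group or a carboxylic acid in place of the terminal amine would keep the reading of compound 3 at 260 nM.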